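Growth inhibition notes: fluoro to dimethylamino on compound 2

A few compounds are considered here, and "the series" means these few. Any claim that something is new, unique, unknown or untested is made for them only; others in the source may bear on it.

Values so far in a functional assay on Gurav cells (Homo sapiens) for inhibition, read by sulforhodamine B assay (a higher number here means a weaker inhibitor of growth, a lower number a stronger inhibitor of growth), for two compounds
compound 1 `Fc1ccc(-c2ccc(-c3ccc(-c4nc5ccccc5[nH]4)cc3)cc2)cc1` gives 100000 nM
compound 2 `Oc1cccc2[nH]c(-c3ccc(-c4ccc(-c5ccc(F)cc5)cc4)cc3)nc12` gives 2860 nM

Compound 2 holds the lower of the two numbers, with 2860 nM in this assay as the best reading so far. Within the data shown here, the only measured step, hydroxy in place of hydrogen on an aromatic carbon, is large: a 35-fold lower number from compound 1 to compound 2 (1.54 log units; beyond the scatter) in this assay for that one change.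

The next compound is compound 3 `CN(C)c1ccc(-c2ccc(-c3ccc(-c4nc5c(O)cccc5[nH]4)cc3)cc2)cc1`, which keeps the hydroxy. Its change from compound 2 is dimethylamino in place of fluoro on an aromatic carbon with dimethylamino in place of fluoro on an aromatic carbon, para to a large group.

Among the measured compounds shown here, no measured step touches this place, and no other group has been compared with fluoro there. The hydroxy step concerns a different place, so it sets neither a size nor a direction for this change. No step beyond the scatter is therefore expected, though the direction is open and the range stays wide. The expected step is a 1.4-fold lower number from compound 2 to compound 3 (0.16 log units; within the scatter) on this estimate. Compound 3 is expected at 2000 nM with an estimated range of 400 nM to 10000 nM for most repeat measurements.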

Compound 3, concentration for 50% growth inhibition: 8210 nM
For compound 3 the middle estimate is 4.1-fold (0.61 log units) below the measured one; the range from low to high includes it.
By their numbers in this assay, from the lowest: compound 2; then compound 3; then compound 1.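

In this assay, the change from fluoro to dimethylamino gives a 2.9-fold higher number from compound 2 to compound 3 (0.46 log units; beyond the scatter), so this place, para to a large group, responds to the group it carries, and the first comparison there falls in favour of fluoro, though only modestly. Of the two groups compared at this place, fluoro holds the lower number, while dimethylamino differs from it in two counted ways: three heavy atoms against one, and one hydrogen-bond acceptor against none, and a single pair cannot separate these differences. No measurement is available that bears on the origin of this step.

As far as these compounds go, it remains open where other groups at this place, such as a primary amine, methoxy, a carboxylic acid or a longer alkyl chain, would fall relative to fluoro and dimethylamino, and whether any of them would give a lower number than fluoro. Also open, from the compounds shown here alone, is whether the change from 4-fluorophenyl to 4-(dimethylamino)phenyl gives a step of similar size and direction on the core of compound 1, which lacks the hydroxy.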